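A few compounds are considered here, and "the series" means these few. Any claim that something is new, unique, unknown or untested is made for them only; others in the source may bear on it.

Working notes on the series. In a functional assay on a cell-free system (plasma, Homo sapiens), with a stated time of 3 min (on this read-out lower numbers stand for stronger inhibition and higher numbers for weaker inhibition), compound 1 (`O=C(NCc1cc(Cl)ccc1-n1cnnn1)[C@@H]1C[C@@H]2C[C@@H]2N1C(=O)[C@H](O)CC1CC1`) gives 1700 nM and compound 3 (`O=C(NCc1cc(Cl)ccc1-n1cnnn1)[C@@H]1[C@@H]2C[C@@H]2CN1C(=O)[C@H](O)Cc1ccccn1`) gives 1700 nM. Compound 2 (`Cc1cccc([C@@H](O)C(=O)N2N=CC[C@H]2C(=O)NCc2cc(Cl)ccc2-n2cnnn2)c1`) gives 830 nM, the lowest of the three numbers, and its gap to each of the other two lies beyond the scatter. Compound 4 (`O=C(NCc1cc(Cl)ccc1-n1cnnn1)[C@@H]1CC=NN1C(=O)[C@H](O)c1ccccc1`) has not yet been measured. It differs from compound 2 by hydrogen in place of methyl on an aromatic carbon, so that 3-methylphenyl becomes phenyl. For the measured compounds named here, no measured pair shows this change, and the expectation rests on the structures alone. The expected step is small, an estimated 1.2-fold higher number from compound 2 to compound 4 (0.08 log units; within the scatter), toward a slightly higher number and within the scatter in this assay. Compound 4 is estimated at 1000 nM, with an expected range from 400 nM to 2500 nM.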

Compound 4, half-maximal inhibitory concentration: 840 nM
The estimate for compound 4 lay 1.2-fold (0.08 log units) above the measured number; the range from low to high includes it.
By their numbers in this assay, from the lowest: compounds 2 and 4 (each within the scatter of the next); then compounds 1 and 3 (each within the scatter of the next).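

Going from 3-methylphenyl to phenyl gives a 1.0-fold higher number from compound 2 to compound 4 (0.01 log units; within the scatter) in this assay. For the compounds shown here, this is the only pair that differs in one place, and it shows that this methyl on the aromatic ring can be replaced by hydrogen with no change beyond the scatter. Nothing in hand bears on the reason for this result.

At this place only methyl and hydrogen can be compared so far. On these data alone, whether a methoxy group, an amine or a carboxylic acid there would shift the number remains open.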